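The source may report more compounds than this note shows. Statements on the series, on what has been measured and on what is new or still open speak of the compounds shown alone.

Within the data shown here, compound 3 `C=CCn1c(=O)/c(=C\c2cccc(Cl)c2Cl)[nH]c(=O)/c1=C\c1ccccc1OC` is the only member of this small series with a numerical result: in a functional assay on Huh-7 cells (Homo sapiens) for cytotoxicity, read by CCK-8 assay, with a stated time of 72 h (on this read-out lower numbers stand for stronger inhibition and higher numbers for weaker inhibition), compound 3 gives 1200 nM. Its two relatives carry no number at all. Compound 1 `COc1ccccc1/C=c1/[nH]c(=O)/c(=C\c2ccccc2OC)n(C)c1=O` is recorded in this assay as "not active" (no number reported), and compound 2 `COc1ccccc1/C=c1/[nH]c(=O)/c(=C\c2cccc(Cl)c2Cl)[nH]c1=O` likewise as "not active" (no number reported). Compound 4 `C=CCn1c(=O)/c(=C\c2ccccc2OC)[nH]c(=O)/c1=C\c1ccccc1OC` has not yet been tested; it differs from compound 3 by 2-methoxyphenyl in place of 2,3-dichlorophenyl on a double-bonded chain carbon bound to an aromatic carbon. Compound 1 carries two 2-methoxyphenyl groups, as compound 4 would. Because compound 1 stands at "not active" (no number reported), a weakening beyond the usual scatter is expected for the step of a 5.0-fold higher number from compound 3 to compound 4 (0.70 log units; beyond the scatter). Compound 4 is therefore estimated at 6000 nM in this assay, within a range of 2000 nM to 30000 nM, with a real chance that no number is obtained.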

Compound 4, half-maximal inhibitory concentration: 21200 nM
Estimate against measurement, compound 4: 3.5-fold (0.55 log units) below, and the stated range covers the measured number.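

In this assay, 2-methoxyphenyl in place of 2,3-dichlorophenyl on a double-bonded chain carbon bound to an aromatic carbon gives an 18-fold higher number from compound 3 to compound 4 (1.25 log units; beyond the scatter), the first measured size for a change at this place. The number is large, so the 2,3-dichlorophenyl group matters here, yet compound 4 still gives a number, whereas compound 1 is recorded as "not active" (no number reported). Nothing shown gives a reason for this loss. From the compounds shown here alone, it remains open how a chlorophenyl group with a single chlorine or an aminophenyl group would fare at this place.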